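The source may hold more compounds than are shown below. What is called first, only, known or untested is meant among the compounds shown, and "the series" means these compounds.

Working notes on the series. In a functional assay on U-87MG ATCC cells for antiproliferative activity against U-87 MG (Homo sapiens), read by MTT assay, with a stated time of 72 h (on this read-out lower numbers stand for stronger inhibition and higher numbers for weaker inhibition), compound 1 `Cc1nn(C)c(Oc2cccc(F)c2)c1/C=N\CCCCCOc1cc2oc(=O)cc(C)c2cc1Cl` gives 9870 nM. Compound 2 `Cc1nn(C)c(Oc2ccc(F)cc2)c1/C=N\CCCCCOc1cc2oc(=O)cc(C)c2cc1Cl` returns only a limit of the assay, > 25000 nM. Compound 3 `Cc1nn(C)c(Oc2cccc(F)c2F)c1/C=N\CCCCCCOc1cc2oc(=O)cc(C)c2cc1Cl` also returns a limit, > 25000 nM, so it stands at the limit of > 25000 nM in this assay, at which 2 of the 3 values shown sit, and has no point number of its own. Among the compounds with values here, the one measured step, an at least 2.5-fold higher number from compound 1 to compound 2 (0.40 log units; beyond the scatter), concerns moving a fluorine on the same phenoxy group and was beyond the scatter. Compound 4 `Cc1nn(C)c(Oc2cccc(Cl)c2)c1/C=N\CCCCCCOc1cc2oc(=O)cc(C)c2cc1Cl` carries 3-chlorophenyl in place of 2,3-difluorophenyl on an oxygen on an aromatic ring. Its 3-chlorophenoxy group resembles the 3-fluorophenoxy group of compound 1, whose value of 9870 nM is the only point number shown. Within the data shown here, no measured step covers the change from a difluorophenyl to a chlorophenyl. For compound 4 the expected step is an at least 1.6-fold lower number from compound 3 to compound 4 (0.22 log units; that floor lies within the scatter). Compound 4 is estimated at 15000 nM, between 5000 nM and 40000 nM.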

Compound 4, half-maximal inhibitory concentration: 8460 nM
The estimate for compound 4 lay 1.8-fold (0.25 log units) above the measured number; measured number inside the range.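

In this assay, 3-chlorophenyl in place of 2,3-difluorophenyl on the oxygen gives an at least 2.9-fold lower number from compound 3 to compound 4 (0.47 log units; beyond the scatter). The earlier step only moved a fluorine on the phenoxy group, whereas this one shows that exchanging the halogens on that ring also moves the read-out beyond the scatter, here towards stronger inhibition. Compound 3 holds only a limit, and the full size of the step cannot be read from it: the limit of > 25000 nM in this assay, at which 2 of the 4 values shown sit.

As far as these compounds go, whether the chlorine or the loss of the fluorines drives the step remains open. So does how a methoxy group or an amine at this ring would read.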